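This account rests on a few compounds, and the source may have more. Where it says the series, first, only, none or still open, it means among the compounds named here.

Compound 1 `C=CCCSC[C@H](NC(=O)c1cc(OC)c(OC)c(OC)c1)C(=O)OC` gives 27300 nM in an assay on RAW264.7 cells for antagonist activity at Toll-like receptor 2 (Mus musculus), read by Griess assay, with a stated time of 24 h; a higher number here means a weaker inhibitor, a lower number a stronger inhibitor. Compound 2 `C=CCCSC[C@H](NC(=O)c1cc(O)c(O)c(O)c1)C(=O)OC` stands at the higher of the two numbers, giving 57800 nM in this assay, a gap from compound 1 that lies beyond the usual scatter. Compound 3 `COC(=O)[C@H](CSCc1ccc(F)cc1)NC(=O)c1cc(O)c(O)c(O)c1` carries 4-fluorophenyl in place of allyl on a saturated chain carbon bound to a sulfur and has not yet been tested. Within the data shown here, no measured pair shows this change, so the step is expected to be small, likely no more than the scatter, with no clear direction. The expected step from a 1.4-fold lower number from compound 2 to compound 3 (0.16 log units; within the scatter) reflects this. Compound 3 is estimated at 40000 nM, with a range from 12000 nM to 120000 nM.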

Compound 3, half-maximal inhibitory concentration: 50200 nM
Compound 3: middle estimate off by 1.3-fold (0.10 log units), on the low side, within the range that was stated.
By their numbers in this assay, from the lowest: compounds 1, 3 and 2 (each within the scatter of the next, the first and the last beyond it).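

With 4-fluorophenyl in place of allyl on a saturated chain carbon bound to a sulfur, the step is a 1.2-fold lower number from compound 2 to compound 3 (0.06 log units; within the scatter) in this assay. The position thus takes a group of seven heavy atoms with a six-membered aromatic ring in place of one of three heavy atoms with no ring, and the reading stays level with that of compound 2. No measurement shown here offers an explanation for this.

From the compounds shown here alone, how an amine or a carboxylic acid would read at this position remains open. Also open, going by these compounds, is whether 4-fluorophenyl would read the same on the core of compound 1.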